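A few compounds are considered here, and "the series" means these few. Any claim that something is new, unique, unknown or untested is made for them only; others in the source may bear on it.

Readings in a functional assay on SGC-7901 cells (Homo sapiens) for antiproliferative activity, read by sulforhodamine B assay, with a stated time of 72 h; a higher number here means a weaker inhibitor, a lower number a stronger inhibitor:
- Compound 1 `Cc1cccc(NC(=S)N/N=C/c2ccc3ccccc3n2)c1`: > 100000 nM (a limit of the assay, not a number)
- Compound 2 `Cc1ccc(NC(=S)N/N=C/c2ccc3ccccc3n2)cc1`: 92900 nM
- Compound 3 `S=C(N/N=C/c1ccc2ccccc2n1)Nc1ccc(Cl)cc1`: not yet measured

Going by the values given here, compound 2 holds the only actual number so far in this assay. The other reading is the limit of > 100000 nM in this assay, at which 1 of the 2 values shown sits.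

The next change, from compound 2 to compound 3, is chloro in place of methyl on an aromatic carbon, para to a large group, so 4-methylphenyl becomes 4-chlorophenyl.

Among the compounds with values here, the only measured step is an at least 1.0-fold lower number from compound 1 to compound 2 (0.03 log units; that floor lies within the scatter). It involves no chloro group and one of its ends is a limit, so it gives no measured size for this change. No step beyond the scatter is therefore expected in this assay, and no direction can be favoured with confidence. The expected change is a 1.3-fold lower number from compound 2 to compound 3 (0.12 log units; within the scatter). For compound 3 the estimate is 70000 nM, with an expected range of 20000 nM to 100000 nM.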

Compound 3, half-maximal inhibitory concentration: 87600 nM
The estimate for compound 3 lay 1.3-fold (0.10 log units) below the measured number; low and high end bracket the measured number.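

Chloro in place of methyl on this aromatic carbon, para to a large group, now has a measured size in this assay. The step is a 1.1-fold lower number from compound 2 to compound 3 (0.03 log units; within the scatter), so this single exchange gives no separation between 4-methylphenyl and 4-chlorophenyl. The other new step gives only a floor, an at least 1.1-fold lower number from compound 1 to compound 3 (0.05 log units; that floor lies within the scatter), and compound 1 remains a limit of the assay, not a number: the limit of > 100000 nM in this assay, at which 1 of the 3 values shown sits.

Going by these compounds, it remains open whether any group on this aromatic carbon can move the number beyond the scatter, and an amine, a carboxylic acid or a longer alkyl chain would test this. On these data alone, it also remains open whether the flat response to chloro and methyl would persist with changes elsewhere on the shared core.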